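This account rests on a few compounds, and the source may have more. Where it says the series, first, only, none or still open, it means among the compounds named here.

Measured compounds:
- compound 1, `O=S(=O)(NCCNCc1cccc2ccccc12)c1cc(C(F)(F)F)cc(C(F)(F)F)c1`: 16000 nM
- compound 2, `O=S(=O)(NCCNCc1ccc(-c2ccccc2)cc1)c1cc(C(F)(F)F)cc(C(F)(F)F)c1`: 2700 nM

In a functional assay on HT-29 cells (Homo sapiens) for inhibition, read by MTT assay, with a stated time of 72 h (on this read-out lower numbers stand for stronger inhibition of growth and higher numbers for weaker inhibition of growth), compound 2 holds the lowest of the two numbers, and compound 1 sits well beyond the scatter from it. Compound 3, `CC(C)(C)c1ccc(CNCCNS(=O)(=O)c2cc(C(F)(F)F)cc(C(F)(F)F)c2)cc1`, has not yet been measured in this assay; it differs from compound 2 by tert-butyl in place of phenyl on an aromatic carbon. For the measured compounds named here, with no measured step of this kind to draw on, the step is expected to be small, in either direction or none beyond the scatter, so that a 1.3-fold higher number from compound 2 to compound 3 (0.11 log units; within the scatter) is the estimated change. Compound 3 is accordingly expected to give 3500 nM, within a range from 1200 nM to 10000 nM.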

Compound 3, concentration for 50% growth inhibition: 14000 nM
Compound 3: middle estimate off by 4.0-fold (0.60 log units), on the low side; measured number outside the range, above it.
By their numbers in this assay, from the lowest: compound 2; then compounds 3 and 1 (each within the scatter of the next).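

In (this assay), tert-butyl in place of phenyl on an aromatic carbon, para to a large group, proves no neutral exchange, giving (a 5.2-fold higher number from compound 2 to compound 3 (0.71 log units; beyond the scatter)). 4-(tert-butyl)phenyl in place of naphthalen-1-yl on a saturated chain carbon bound to an amine nitrogen gives no separation (a 1.1-fold lower number from compound 1 to compound 3 (0.06 log units; within the scatter)), so of these three compounds only compound 2 stands apart. No measurement shown here accounts for this result.

The compounds shown leave open whether the lower number of compound 2 depends on an aromatic ring at this carbon or on any ring. A cyclohexyl or pyridin-3-yl group there would bear on that question.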